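The source may hold more compounds than are shown below. What is called first, only, known or untested is meant among the compounds shown, and "the series" means these compounds.

The series rests on a shared amide core in which a benzoyl ring is joined to a fused bicyclic amine. Compound 1, `COc1ccc(C(=O)Nc2nc3cc(C)cc(C)c3s2)cc1`, carries methoxy on the benzoyl ring and two methyl groups on the bicyclic part. In a functional assay on SK-HEP1 cells (Homo sapiens) for antiproliferative activity, read by sulforhodamine B assay (a lower number here means a stronger inhibitor of growth, a higher number a weaker inhibitor of growth), compound 1 gives > 10 ug/mL, which is a limit of the assay and not a number, as marked by the limit of > 10 ug/mL in this assay, at which 1 of the 3 values shown sits. Compound 2, `Cc1cc(C)c2sc(NC(=O)c3ccc(C#N)cc3)nc2c1`, differs from compound 1 by cyano in place of methoxy on an aromatic carbon and in this assay compound 2 gives 1.18 ug/mL. This change yields an at least 8.4-fold lower number from compound 1 to compound 2 (0.92 log units; beyond the scatter).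

Compound 3, `COc1ccc(C(=O)Nc2nc3c(OC)cccc3s2)cc1`, keeps the methoxy on the benzoyl ring but carries a different bicyclic core, bearing its own methoxy; the difference between the two cores is not broken down here. In this assay compound 3 gives 2.11 ug/mL, and its number and that of compound 2 lie within the usual scatter of each other.

Compound 4, `COc1cccc2sc(NC(=O)c3ccc(C#N)cc3)nc12`, has not yet been measured. It differs from compound 3 by cyano in place of methoxy on an aromatic carbon, the same change that separates compound 1 from compound 2. The step is expected to be a 4.2-fold lower number from compound 3 to compound 4 (0.63 log units; beyond the scatter), which rests on the step of an at least 8.4-fold lower number from compound 1 to compound 2 (0.92 log units; beyond the scatter) and on the value of compound 3 in this assay, 2.11 ug/mL. Compound 4 is therefore estimated at 0.5 ug/mL. For compound 4 the likely range runs from 0.2 ug/mL to 1.5 ug/mL.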

Compound 4, concentration for 50% growth inhibition: > 10 ug/mL
Compound 4 ended at the assay's limit; the forecaster's own chance of this, stated with the estimate: 3%; middle value at least 20-fold (1.30 log units) from the limit.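

In this assay, cyano in place of methoxy on an aromatic carbon, para to a large group, gives an at least 4.7-fold higher number from compound 3 to compound 4 (0.67 log units; beyond the scatter). Set beside the earlier step, this shows that the change does not carry over from the core of compound 1 to the core of compound 3, and that the result depends on the core it is made on: the same change on two cores in this assay, an at least 8.4-fold lower number (0.92 log units; beyond the scatter) from compound 1 to compound 2 and an at least 4.7-fold higher number (0.67 log units; beyond the scatter) from compound 3 to compound 4, at least 40-fold (1.60 log units) apart, beyond the scatter of two such steps. Compound 4 gives > 10 ug/mL, a limit of the assay and not a number, so the full size of this step remains unknown, and two cores do not yield a rule for the wider series: the limit of > 10 ug/mL in this assay, at which 2 of the 4 values shown sit.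

The compounds shown leave open which feature separating the two cores decides the direction of the step, the two methyl groups of the core of compound 1 or the methoxy on the core of compound 3. They also leave open how other groups at the same place on the benzoyl ring, such as an amine, a carboxylic acid or a longer chain, would behave on each core.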